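Removing One Chloro from a Dichloro Fused Core

A few compounds are considered here, and "the series" means these few. Any claim that something is new, unique, unknown or untested is made for them only; others in the source may bear on it.

compound 1 `ClCc1cccc(Cn2cnc3ncnc(Cl)c32)c1`: 6760 nM
compound 2 `ClCc1ccc(Cn2cnc3nc(Cl)nc(Cl)c32)cc1`: 6020 nM

In a functional assay on MDA-MB-231 cells (Homo sapiens) for cytotoxicity, read by sulforhodamine B assay, with a stated time of 48 h (a higher number here means that more compound is tolerated, a lower number that less compound is tolerated), compound 2 gives 6020 nM, and compound 1 gives 6760 nM. The two numbers sit within the usual scatter of each other, so neither compound can be set apart from the other on this measurement.

Compound 3 `ClCc1ccc(Cn2cnc3ncnc(Cl)c32)cc1` differs from compound 2 in one place: hydrogen in place of chloro on an aromatic carbon. Among the compounds with values here, no measured pair here shows what this change does on its own. The two measured compounds differ in more than one place, and their numbers are within the scatter of each other, so the shared core appears to tolerate some variation without the number moving far. The step from compound 2 to compound 3 in this assay is expected to be small, in the direction of slightly more compound tolerated or none beyond the scatter, and is estimated as a 1.2-fold higher number from compound 2 to compound 3 (0.10 log units; within the scatter). Compound 3 is therefore expected to give about 7500 nM, with a range from 3000 nM to 18000 nM.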

Compound 3, concentration lethal to 50% of the cells: 6300 nM
For compound 3 the middle estimate is 1.2-fold (0.08 log units) above the measured one; measured number inside the range.
By their numbers in this assay, from the lowest: compounds 2, 3 and 1 (each within the scatter of the next).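

In this assay, within the data shown here, hydrogen in place of chloro on an aromatic carbon, between two ring nitrogen atoms, gives a 1.0-fold higher number from compound 2 to compound 3 (0.02 log units; within the scatter) and makes this the first pair here that differs in one place only. Among these compounds, this position can therefore be read on its own for the first time: on this measurement, the shared core with chloro there cannot be told apart from the shared core with hydrogen there, so this chloro shows no measurable bearing on the cytotoxicity read-out. Nothing measured here offers an explanation for this result.

The compounds shown leave open how an amine, a methoxy group or a longer chain at this position would read against chloro and hydrogen. They also leave open whether the chloro group that remains in compound 3 could be exchanged for hydrogen with an equally small step.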